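A few compounds are considered here, and "the series" means these few. Any claim that something is new, unique, unknown or untested is made for them only; others in the source may bear on it.

Of the compounds shown here, two have numbers so far in an in vitro ADME assay on microsomes from liver (Mus musculus) for metabolic stability; on this read-out higher numbers stand for fast clearance and lower numbers for slow clearance. Compound 1 `Cc1cc(Nc2ccc(C(F)(F)F)cc2)n2nc(C3CC3)nc2n1` gives 8.6 mL.min-1.g-1. Compound 2 `COCCc1nc2nc(C)cc(Nc3ccc(S(F)(F)(F)(F)F)cc3)n2n1` gives 14.1 mL.min-1.g-1, the highest of the two numbers; the nearest to it is compound 1, and the gap between the two lies within the scatter, so neither can be called cleared faster or slower than the other. Among the measured compounds shown here, the two structures differ in more than one place, so no single step between them is set out.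

Compound 3 `COCCc1nc2nc(C)cc(Nc3ccc(C(F)(F)F)cc3)n2n1` is not yet measured in this assay. It differs from compound 2 in one place: a group of 4 heavy atoms (1 carbon, 3 fluorine; no ring) in place of a group of 6 heavy atoms (5 fluorine, 1 sulfur; no ring), on an aromatic carbon. Compound 1 also carries a trifluoromethyl on the same kind of aromatic carbon and gives 8.6 mL.min-1.g-1, but its core differs from that of compound 3, so it serves only as a loose reference. For the measured compounds named here, with no measured step for this pair, the expectation rests on the closeness of the two known values. The step from compound 2 to compound 3 in this assay is expected to be small, a 1.4-fold lower number from compound 2 to compound 3 (0.15 log units; within the scatter), leaning lower and not clearly beyond the scatter. Compound 3 is estimated at 10 mL.min-1.g-1, within 5 mL.min-1.g-1 to 20 mL.min-1.g-1.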

Compound 3, intrinsic clearance in microsomes: 14.3 mL.min-1.g-1
For compound 3 the middle estimate is 1.4-fold (0.16 log units) below the measured one, within the range that was stated.
By their numbers in this assay, from the lowest: compounds 1, 2 and 3 (each within the scatter of the next).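

In this assay, among the compounds shown here, trifluoromethyl in place of the group of 6 heavy atoms (5 fluorine, 1 sulfur) on the aromatic carbon gives a 1.0-fold higher number from compound 2 to compound 3 (0.01 log units; within the scatter) as the first direct reading at this position, and the two groups cannot be told apart there on this read-out. The other place on the series now has a direct reading as well: 2-methoxyethyl in place of cyclopropyl on an aromatic carbon gives a 1.7-fold higher number from compound 1 to compound 3 (0.22 log units; within the scatter) and so separates the two groups no more than the first change does. No measurement at hand bears on the reason for either result.

Both single changes stay within the scatter, so these compounds leave open whether any group at either place can shift clearance beyond it. A nitrile or a chlorine on the aromatic carbon of the six-membered ring, or an amine or a longer chain in place of 2-methoxyethyl, would show whether the flat reading across these three compounds holds for groups of a different kind.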